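Swapping Trifluoromethyl for Fluoro on a Weak Inhibitor

The source may report more compounds than this note shows. Statements on the series, on what has been measured and on what is new or still open speak of the compounds shown alone.

Compound 3, `Cc1c(C(=O)N/N=C\c2ccc(C(F)(F)F)cc2)oc2cccc(O)c12`, was tested in a functional assay on PC-3 cells (Homo sapiens) for inhibition; on this read-out higher numbers stand for weaker inhibition and lower numbers for stronger inhibition. For compound 3 the result is only a limit, >= 40000 nM, not a number. Compound 1, `Cc1c(C(=O)N/N=C\c2ccccc2F)oc2cccc(O)c12`, likewise gives only a limit, >= 40000 nM. Compound 2, `Cc1c(C(=O)N/N=C\c2cccc(F)c2O)oc2cccc(O)c12`, gives 12700 nM. Among the compounds with values here, the single measured step, an at least 3.1-fold lower number from compound 1 to compound 2 (0.49 log units; beyond the scatter), alters a different part of the molecule and so offers no direct guide here. Compound 4, `Cc1c(C(=O)N/N=C\c2ccc(F)cc2)oc2cccc(O)c12`, differs from compound 3 by fluoro in place of trifluoromethyl on an aromatic carbon. Within the data shown here, because compound 3 sits at the limit of >= 40000 nM in this assay, at which 2 of the 3 values shown sit, and no measured step covers this change, no shift beyond the scatter is expected. Compound 4 is therefore estimated at 40000 nM, within a range of 15000 nM to 90000 nM. The expected step of a number no higher from compound 3 to compound 4 (the limit leaves the size open) stays within the scatter.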

Compound 4, half-maximal inhibitory concentration: >= 40000 nM
Compound 4 was reported as a limit; the forecaster's own chance of this, stated with the estimate: 70%; the middle value sits exactly at the limit.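

In this assay compound 4 sits at the same limit as compound 3, so fluoro and trifluoromethyl on this aromatic carbon both leave inhibition out of reach of a readable number, and the steps to compound 4 from compound 3 and from compound 1 cannot be read: the limit of >= 40000 nM in this assay, at which 3 of the 4 values shown sit.

Within the data shown here, the one readable comparison is an at least 3.1-fold higher number from compound 2 to compound 4 (0.49 log units; beyond the scatter), and so far only the compound with 3-fluoro-2-hydroxyphenyl escapes the limit.

On these data alone, whether the hydroxyl of that group alone accounts for this stays open, as does whether an amine or a carboxylic acid on this aromatic carbon would give a readable number.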